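This account rests on a few compounds, and the source may have more. Where it says the series, first, only, none or still open, it means among the compounds named here.

Compounds measured so far:

compound 1 `CC(C)=CCN1C(=O)N(Cc2ccccc2)S(=O)(=O)n2cccc21`, in an ADME assay on MT4 cells (Homo sapiens) for cytotoxicity, read by MTT assay, with a stated time of 5 days (on this read-out lower numbers stand for higher toxicity in this test and higher numbers for lower toxicity in this test), compound 1 gives 226000 nM
compound 2 `Cc1ccc(CN2C(=O)N(Cc3ccccc3)S(=O)(=O)n3cccc32)cc1`, in which compound 2 gives 241000 nM
compound 3 `O=C1N(Cc2ccc(F)cc2)c2cccn2S(=O)(=O)N1Cc1ccccc1`, in which compound 3 gives 150000 nM

All three compounds share one core and differ only in the group carried on a saturated chain carbon bound to an amide-type nitrogen in a ring. On the numbers shown, compound 3 sits level with the other two: the steps of a 1.5-fold lower number from compound 1 to compound 3 (0.18 log units; within the scatter) and a 1.6-fold lower number from compound 2 to compound 3 (0.21 log units; within the scatter) both stay within the scatter, as does a 1.1-fold higher number from compound 1 to compound 2 (0.03 log units; within the scatter). Compound 4 `N#Cc1cccc(CN2C(=O)N(Cc3ccccc3)S(=O)(=O)n3cccc32)c1` is the next step out from compound 3, with the change (3-cyanophenyl in place of 4-fluorophenyl on a saturated chain carbon bound to an amide-type nitrogen in a ring). Among the compounds with values here, no measured pair carries this exact change; the nearest are the step from compound 1 to compound 3, where a 4-fluorophenyl arrives, and the step from compound 2 to compound 3, where fluoro replaces methyl, neither of which moves the number beyond the scatter. Swapping one substituted phenyl for another is therefore expected to leave the read-out about where it is, and the expected step is a 1.3-fold higher number from compound 3 to compound 4 (0.10 log units; within the scatter). Compound 4 is estimated at 190000 nM, with a range from 95000 nM to 380000 nM.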

Compound 4, half-maximal cytotoxic concentration: > 318000 nM
Compound 4: only a limit was reported; the forecaster's own chance of this, stated with the estimate: 25%; middle value at least 1.6-fold (0.22 log units) from the limit.
By their numbers in this assay, from the lowest: compounds 3, 1 and 2 (each within the scatter of the next). At a limit, above all of these: compound 4.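

Within the data shown here, at this position, on a saturated chain carbon bound to an amide-type nitrogen in a ring, the earlier swaps all stayed within the scatter, but in this assay 3-cyanophenyl in place of 4-fluorophenyl gives the first step beyond it (an at least 2.1-fold higher number from compound 3 to compound 4 (0.32 log units; beyond the scatter)), towards lower toxicity in this test. The other two steps (an at least 1.3-fold higher number from compound 2 to compound 4 (0.12 log units; that floor lies within the scatter)) and (an at least 1.4-fold higher number from compound 1 to compound 4 (0.14 log units; that floor lies within the scatter)) have floors within the scatter, and compound 4 is not shown to differ beyond the scatter from compound 2 or compound 1. The reading for compound 4 is a limit, not an exact number: the limit of > 318000 nM in this assay, at which 1 of the 4 values shown sits.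

How far compound 4 truly lies past that limit stays open, as does whether the nitrile itself or its place on the ring matters, with no 4-cyanophenyl or 3-fluorophenyl among the compounds shown. On these data alone, an amine, a carboxylic acid or a longer chain at this position also remains untested here.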